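A few compounds are considered here, and "the series" means these few. Any claim that something is new, unique, unknown or untested is made for them only; others in the source may bear on it.

In a functional assay on SW480 cells (Homo sapiens) for antiproliferative activity, read by MTT assay, with a stated time of 72 h (on this read-out higher numbers stand for weaker inhibition and lower numbers for stronger inhibition), compound 1 `O=c1c(CSC(=S)N2CCCCC2)coc2cc(Cl)ccc12` gives 790 nM, the lowest of the two numbers measured here. Compound 2 `O=c1c(CSC(=S)N2CCCC2)coc2cc(Cl)ccc12` gives 7800 nM in this assay. Compound 3 `CC(C)N(C(=S)SCc1coc2cc(Cl)ccc2c1=O)C(C)C` is reported in this assay only as a limit, > 25000 nM, which is the limit of > 25000 nM in this assay, at which 1 of the 3 values shown sits. Every measured step changes the amine attached to the thiocarbonyl carbon: a 9.9-fold higher number from compound 1 to compound 2 (0.99 log units; beyond the scatter), an at least 31-fold higher number from compound 1 to compound 3 (1.50 log units; beyond the scatter), and an at least 3.2-fold higher number from compound 2 to compound 3 (0.50 log units; beyond the scatter). Compound 4 `O=c1c(CSC(=S)N2CCCCC2)coc2ccccc12` keeps the piperidin-1-yl group of compound 1 and changes a different part of the shared core: hydrogen in place of chloro on an aromatic carbon. Within the data shown here, no measured step touches this position, so the measured steps offer no direct guide to the size of this change, and the amine portion, which drove all measured steps, is untouched. The step in this assay is therefore expected to be small, a 1.9-fold higher number from compound 1 to compound 4 (0.28 log units; within the scatter), possibly within the scatter. Compound 4 is estimated at 1500 nM, with a range from 500 nM to 5000 nM.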

Compound 4, half-maximal inhibitory concentration: 1200 nM
Estimate against measurement, compound 4: 1.3-fold (0.10 log units) above, and the stated range covers the measured number.
By their numbers in this assay, from the lowest: compounds 1 and 4 (each within the scatter of the next); then compound 2. At a limit, above all of these: compound 3.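

In this assay, this is the only step shown at the aromatic carbon that carries the chloro group, and hydrogen in place of chloro gives a 1.5-fold higher number from compound 1 to compound 4 (0.18 log units; within the scatter). With the piperidin-1-yl group in place, the chloro group can therefore be removed and the difference stays within the usual scatter, whereas a change of the amine alone gives a 9.9-fold higher number from compound 1 to compound 2 (0.99 log units; beyond the scatter). Nothing shown here explains why the step at this position is so small.

Going by these compounds, it remains open whether a fluoro, bromo or methoxy group on this carbon would give a number close to those of compound 1 and compound 4, or one beyond the scatter. On these data alone, it is also open whether hydrogen in place of chloro would give an equally small step with the pyrrolidin-1-yl group of compound 2.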